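Methoxy for chloro on the outer aryl ring

The source may hold more compounds than are shown below. What is called first, only, known or untested is meant among the compounds shown, and "the series" means these compounds.

Three compounds share one core. Compound 1 `N=C(N)c1ccc(-c2ccc(-c3cc(Cl)cc(Cl)c3)s2)cc1` gives 1750 nM in a functional assay on PC-3 cells (Homo sapiens) for inhibition, read by sulforhodamine B assay, with a stated time of 48 h; on this read-out higher numbers stand for weaker inhibition of growth and lower numbers for stronger inhibition of growth. Compound 3 `COc1cc(OC)cc(-c2ccc(-c3ccc(C(=N)N)c(F)c3)s2)c1` gives 1300 nM in this assay, and compound 2 `N=C(N)c1ccc(-c2ccc(-c3ccc(Cl)cc3)s2)cc1F` gives 394 nM, the lowest of the three numbers; its nearest neighbour is compound 3 and its furthest is compound 1, both gaps beyond the scatter. Compound 4 `COc1ccc(-c2ccc(-c3ccc(C(=N)N)c(F)c3)s2)cc1` is not yet measured. It differs from compound 2 in one place: methoxy in place of chloro on an aromatic carbon. For the measured compounds named here, no measured pair shows this change directly; compound 3 with two methoxy groups at 1300 nM sits above compound 2 at 394 nM, while compound 1 with two chloro groups sits higher still. A modest loss in this assay is expected, a 1.8-fold higher number from compound 2 to compound 4 (0.25 log units; within the scatter). Compound 4 is estimated at 700 nM, within 250 nM to 2000 nM.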

Compound 4, concentration for 50% growth inhibition: 4050 nM
For compound 4 the middle estimate is 5.8-fold (0.76 log units) below the measured one; the whole stated range lies below it.
By their numbers in this assay, from the lowest: compound 2; then compounds 3 and 1 (each within the scatter of the next); then compound 4.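

In this assay, for the compounds shown here, methoxy in place of chloro on the aromatic carbon para to a large group gives a 10-fold higher number from compound 2 to compound 4 (1.01 log units; beyond the scatter) as the first direct reading of this change. At this place, the change costs inhibition of growth, and the step is large. The data shown offer no measured explanation for the loss.

Going by these compounds, whether the loss is specific to methoxy or extends to other replacements for chloro stays open. A hydroxyl group or an amine at this place would help to separate those readings.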